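The source may hold more compounds than are shown below. What is called first, only, known or untested is meant among the compounds shown, and "the series" means these compounds.

Measured compounds:
compound 1, `CC(C)[C@@H](NC(=O)c1nc2ccccc2s1)C(=O)N1CCC(c2ccc(Cl)cc2)CC1`, 18 nM
compound 2, `CC(C)[C@@H](NC(=O)c1ccc(F)cc1)C(=O)N1CCC(c2ccc(Cl)cc2)CC1`, 118 nM
compound 3, `CC(C)[C@@H](NC(=O)C1CCCC1)C(=O)N1CCC(c2ccc(Cl)cc2)CC1`, 70 nM

In an assay on THP-1 cells for displacement of a labelled ligand from C-C chemokine receptor type 1 (Homo sapiens) (on this read-out higher numbers stand for weaker inhibition and lower numbers for stronger inhibition), compound 3 gives 70 nM. Among the three measured compounds it has the second highest number: its nearest neighbour is compound 2, at a 1.7-fold lower number from compound 2 to compound 3 (0.23 log units; within the scatter), a gap that stays within the usual scatter; its furthest is compound 1, at a 3.9-fold higher number from compound 1 to compound 3 (0.59 log units; beyond the scatter), which lies beyond it. Compound 1 also stands apart from compound 2, with a 6.6-fold higher number from compound 1 to compound 2 (0.82 log units; beyond the scatter).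

Compound 4, `CC(C)[C@@H](NC(=O)c1ccc(F)c(F)c1)C(=O)N1CCC(c2ccc(Cl)cc2)CC1`, differs from compound 3 in one place: 3,4-difluorophenyl in place of cyclopentyl on a carbonyl carbon. Among the measured compounds shown here, the measured step that bears on this change is the one between compound 2 and compound 3, a 1.7-fold lower number from compound 2 to compound 3 (0.23 log units; within the scatter), where a fluorinated phenyl and the cyclopentyl gave numbers within the scatter of each other. For the measured compounds named here, no measured compound carries a second fluorine on that ring, so nothing is known about what it adds. On this basis compound 4 is expected to land near compound 2, which gives 118 nM, and the step from compound 3 is expected to be small, a 1.4-fold higher number from compound 3 to compound 4 (0.15 log units; within the scatter), not clearly beyond the scatter. The estimate for compound 4 in this assay is 100 nM, with a range from 40 nM to 250 nM.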

Compound 4, half-maximal inhibitory concentration: 14 nM
Beside the measured number, compound 4's estimate is 7.1-fold (0.85 log units) above it; measured number below the stated range.
By their numbers in this assay, from the lowest: compounds 4 and 1 (each within the scatter of the next); then compounds 3 and 2 (each within the scatter of the next).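

In this assay, among the compounds shown here, the phenyl ring on this carbonyl carbon proves far more sensitive to substitution than the earlier compounds could show: one further fluorine, fluoro in place of hydrogen on an aromatic carbon, gives an 8.4-fold lower number from compound 2 to compound 4 (0.93 log units; beyond the scatter). The earlier step between a fluorinated phenyl and cyclopentyl stayed within the scatter, at a 1.7-fold lower number from compound 2 to compound 3 (0.23 log units; within the scatter), yet 3,4-difluorophenyl in place of cyclopentyl gives a 5.0-fold lower number from compound 3 to compound 4 (0.70 log units; beyond the scatter), so a phenyl ring at this place is not simply interchangeable with cyclopentyl. The 1,3-benzothiazol-2-yl group also no longer stands alone at the low end of these numbers, as the change to 3,4-difluorophenyl gives a 1.3-fold lower number from compound 1 to compound 4 (0.11 log units; within the scatter), and nothing shown here explains the size of the fluorine step.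

For the compounds shown here, whether the added fluorine would give the same step without the one already present in compound 2 stays open, as does whether a dichlorophenyl or a cyanophenyl group on the same carbonyl carbon would behave like 3,4-difluorophenyl. It is also unknown whether the fluorine step would carry over to a core with a longer chain in place of the shared branched alkyl group.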